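From piperidin-3-yl to piperazin-1-yl in compound 4

The source may report more compounds than this note shows. Statements on the series, on what has been measured and on what is new or still open speak of the compounds shown alone.

In an ADME assay on microsomes from liver (Mus musculus) for metabolic stability, read by LC-MS, with a stated time of 10 min, tested at 0.5 uM (on this read-out lower numbers stand for a less stable compound and higher numbers for a more stable compound), compound 1 (`c1ccc2c(c1)CN[C@@H](CN(CC[C@@H]1CCCNC1)[C@H]1CCCc3cccnc31)C2`) gives 23%, the lowest of the three measured numbers. Compound 2 (`CN1CCN(CCCN(C[C@H]2Cc3ccccc3CN2C)[C@H]2CCCc3cccnc32)CC1`) gives 43% and compound 3 (`c1cnc2c(c1)CN[C@H](CN(CCCN1CCNCC1)[C@H]1CCCc3cccnc31)C2`) gives 63%, both higher than compound 1 by more than the usual scatter. Compound 4 (`c1ccc2c(c1)CN[C@@H](CN(CCN1CCNCC1)[C@H]1CCCc3cccnc31)C2`) has not been measured yet. It differs from compound 1 in one place: piperazin-1-yl in place of piperidin-3-yl on a saturated chain carbon, two bonds along the chain from an amine nitrogen. Among the measured compounds shown here, no measured pair shows a single change on its own, so any forecast stays loose. Compound 3 also carries piperazin-1-yl and gives 63%, though it differs elsewhere too, so a moderate rise is expected in this assay. The expected step is a number 17 percentage points higher from compound 1 to compound 4 (beyond the scatter). Compound 4 is estimated at 40%, with an expected range from 22% to 60%.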

Compound 4, percent of the compound remaining: 79%
Compound 4: middle estimate off by 39 percentage points, on the low side; measured number outside the range, above it.
By their numbers in this assay, from the lowest: compound 1; then compound 2; then compound 3; then compound 4.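

Placed on a saturated chain carbon, two bonds along the chain from an amine nitrogen, piperazin-1-yl in place of piperidin-3-yl gives a number 56 percentage points higher from compound 1 to compound 4 (beyond the scatter) in this assay, the first single change that can be read on its own here. With the rest of compound 4 the same as compound 1, this one position can strongly move the percent remaining. No available evidence gives a reason for the step.

Still open, as far as these compounds go, is whether another ring, such as morpholin-4-yl or piperidin-1-yl, would do the same here. From the compounds shown here alone, whether the same change holds on other cores also remains unknown.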